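From 4-methylphenyl to 3-chlorophenyl on a shared core

This account rests on a few compounds, and the source may have more. Where it says the series, first, only, none or still open, it means among the compounds named here.

compound 1 `CCCc1ccc(NC2=CC(=O)c3nc4n(c3C2=O)[C@H]2OC[C@@H](O)[C@H]2OC4)cc1`: 1560 nM
compound 2 `CCc1ccc(NC2=CC(=O)c3nc4n(c3C2=O)[C@H]2OC[C@@H](O)[C@H]2OC4)cc1`: 1290 nM
compound 3 `Cc1ccc(NC2=CC(=O)c3nc4n(c3C2=O)[C@H]2OC[C@@H](O)[C@H]2OC4)cc1`: 1420 nM

These three compounds share one core and differ only in the saturated chain on the phenyl ring. In a functional assay on MGC-803 cells (Homo sapiens) for inhibition, read by sulforhodamine B assay (a higher number here means a weaker inhibitor, a lower number a stronger inhibitor), compound 3 gives 1420 nM, a number within the scatter of both of the others, so the three cannot be ranked.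

Compound 4 `O=C1C=C(Nc2cccc(Cl)c2)C(=O)c2c1nc1n2[C@H]2OC[C@@H](O)[C@H]2OC1` is the next to be measured, and it differs from compound 3 as follows: 3-chlorophenyl in place of 4-methylphenyl on an amine nitrogen. In words, this is 3-chlorophenyl in place of 4-methylphenyl on an amine nitrogen.

Going by the values given here, three measured steps bear on this change, though only indirectly, as each alters just the chain on that ring. They are a 1.1-fold higher number from compound 2 to compound 3 (0.04 log units; within the scatter), a 1.1-fold lower number from compound 1 to compound 3 (0.04 log units; within the scatter) and a 1.2-fold lower number from compound 1 to compound 2 (0.08 log units; within the scatter). All three lie within the scatter, so this assay has not separated these chain changes. Among the compounds with values here, no measured compound carries a 3-chlorophenyl group, however, and the steps say nothing direct about one. A shift beyond the scatter is therefore not expected in either direction, though this expectation is loose.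

The expected step is a 1.1-fold lower number from compound 3 to compound 4 (0.04 log units; within the scatter). For compound 4 the estimated value is 1300 nM, with an expected range from 550 nM to 3000 nM.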

Compound 4, half-maximal inhibitory concentration: 1770 nM
For compound 4 the middle estimate is 1.4-fold (0.13 log units) below the measured one, within the range that was stated.
By their numbers in this assay, from the lowest: compounds 2, 3, 1 and 4 (each within the scatter of the next).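

In this assay, 3-chlorophenyl in place of 4-methylphenyl on the amine nitrogen gives a 1.2-fold higher number from compound 3 to compound 4 (0.10 log units; within the scatter), and the comparisons with the two longer chains read a 1.4-fold higher number from compound 2 to compound 4 (0.14 log units; within the scatter) and a 1.1-fold higher number from compound 1 to compound 4 (0.05 log units; within the scatter). The earlier compounds shown here differed only in the length of a saturated chain, whereas this change replaces that chain with a chlorine atom and puts the substituent at 3 rather than 4 on the phenyl ring, yet all four compounds remain within the scatter of one another, so this larger change also gives no difference that this assay can separate. No measurement shown offers an explanation for this flat result.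

From the compounds shown here alone, whether the same holds for a phenyl ring carrying a methoxy group, a nitrile or a carboxylic acid, or for a saturated ring in place of the phenyl ring on this nitrogen, remains open. The compounds shown also leave open how far any change at this position can move the number in this assay.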